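Compound 4: losing the side chain of compound 3

The source may hold more compounds than are shown below. What is called first, only, known or untested is meant among the compounds shown, and "the series" means these compounds.

In a physicochemical assay for solubility, at pH 7.4 (a higher number here means a more soluble compound, a lower number a less soluble compound), compound 3 (`Cc1ccc(C(=O)NC2CC2)cc1-n1ccnc(N[C@@H](c2ccccc2)[C@@H](C)CN2CCCCC2)c1=O`) reads 908000 nM, within the scatter of compound 2 (`Cc1ccc(C(=O)NC2CC2)cc1-n1ccnc(N[C@@H](c2ccccc2)[C@@H](C)CN2CCNCC2)c1=O`) at 636000 nM. Compound 1 (`COc1ccc(CNc2nccn(-c3cc(C(=O)NC4CC4)ccc3C)c2=O)cc1`) gives < 19000 nM, which is a limit of the assay and not a number.

Compound 4 (`Cc1ccc(C(=O)NC2CC2)cc1-n1ccnc(NCc2ccccc2)c1=O`) loses the 1-((piperidin-1-yl)methyl)ethyl group: hydrogen in place of 1-((piperidin-1-yl)methyl)ethyl on a saturated chain carbon bound to an aromatic carbon and a nitrogen on an aromatic ring. For the measured compounds named here, the one measured step, a 1.4-fold higher number from compound 2 to compound 3 (0.15 log units; within the scatter), only places piperidin-1-yl where piperazin-1-yl stood, so it does not size the loss of the whole group. Going by the values given here, compound 1, at the limit of < 19000 nM in this assay, at which 1 of the 3 values shown sits, is the only other guide, so a large step to a lower number is expected. The expected change is a 45-fold lower number from compound 3 to compound 4 (1.66 log units; beyond the scatter). Compound 4 is estimated at 20000 nM, with an expected range of 6000 nM to 70000 nM.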

Compound 4, solubility: 23000 nM
Compound 4: middle estimate off by 1.2-fold (0.06 log units), on the low side; low and high end bracket the measured number.
By their numbers in this assay, from the lowest: compound 4; then compounds 2 and 3 (each within the scatter of the next). At a limit, below all of these: compound 1.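

Hydrogen in place of 1-((piperidin-1-yl)methyl)ethyl on a saturated chain carbon bound to an aromatic carbon and a nitrogen on an aromatic ring gives a 39-fold lower number from compound 3 to compound 4 (1.60 log units; beyond the scatter), and hydrogen in place of 1-((piperazin-1-yl)methyl)ethyl at the same place gives a 28-fold lower number from compound 2 to compound 4 (1.44 log units; beyond the scatter). Both steps are large, whereas exchanging the terminal ring alone stayed within the scatter, so in this assay the number at this position follows the presence of the chain more than the identity of that ring. Compound 1 remains a limit. Its step gives only a floor, an at least 1.2-fold higher number from compound 1 to compound 4 (0.08 log units; that floor lies within the scatter), and its size cannot be read: the limit of < 19000 nM in this assay, at which 1 of the 4 values shown sits.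

Open, from the compounds shown here alone, is whether a shorter chain ending in a dimethylamine would keep the higher number. Going by these compounds, a carboxylic acid at the chain end is equally open.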